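Cytotoxicity of arylpiperazine ketones on Vero cells

This account rests on a few compounds, and the source may have more. Where it says the series, first, only, none or still open, it means among the compounds named here.

Compound 1 `COc1ccc(C(=O)CCN2CCN(c3ccc(F)cc3)CC2)cc1` gives 55000 nM in an ADME assay on Vero cells (Chlorocebus sabaeus) for cytotoxicity, read by resazurin assay, with a stated time of 72 h; on this read-out lower numbers stand for stronger inhibition and higher numbers for weaker inhibition.
Compound 2 `COc1ccc(C(=O)CCN2CCN(c3ccc(C(F)(F)F)cc3)CC2)cc1` gives 135000 nM in this assay.
Compound 3 `O=C(CCN1CCN(c2ccc(F)cc2)CC1)c1ccc(F)c(Br)c1` gives 352000 nM in this assay.

Of the compounds shown here, three sharing a propanone-piperazine core have been measured in this assay, and a fourth, compound 4 `O=C(CCN1CCN(c2ccc(C(F)(F)F)cc2)CC1)c1ccc(F)c(Br)c1`, awaits measurement. Compound 1 has the lowest number of the three. Going from compound 1 to compound 2 the change is trifluoromethyl in place of fluoro on an aromatic carbon, and the step is a 2.5-fold higher number from compound 1 to compound 2 (0.39 log units; beyond the scatter). Going from compound 1 to compound 3 the cores differ by 3-bromo-4-fluorophenyl in place of 4-methoxyphenyl on a carbonyl carbon, and the step is a 6.4-fold higher number from compound 1 to compound 3 (0.81 log units; beyond the scatter). Compound 3 thus stands highest of the three, with compound 2 nearest to it.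

Compound 4 differs from compound 3 by trifluoromethyl in place of fluoro on an aromatic carbon. This is the same change that leads from compound 1 to compound 2, at the same place. Within the data shown here, that single earlier step is the only guide available here, and it is modest. The step expected from compound 3 to compound 4 is therefore estimated at a 2.4-fold higher number from compound 3 to compound 4 (0.38 log units; beyond the scatter), resting on the step of a 2.5-fold higher number from compound 1 to compound 2 (0.39 log units; beyond the scatter) seen once in this series. Since compound 3 already gives 352000 nM, such a step would carry compound 4 well past the highest number seen so far in this series. For compound 4 the expected value in this assay is 850000 nM, with a range of 350000 nM to 2000000 nM.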

Compound 4, half-maximal inhibitory concentration: 66800 nM
Compound 4: middle estimate off by 13-fold (1.10 log units), on the high side; measured number below the stated range.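

In this assay, the step made by trifluoromethyl in place of fluoro on the core of compound 3 is a 5.3-fold lower number from compound 3 to compound 4 (0.72 log units; beyond the scatter), so the change that raised the number on the core of compound 1 lowers it here, and the two steps disagree in direction as well as in size: the same change on two cores in this assay, a 2.5-fold higher number (0.39 log units; beyond the scatter) from compound 1 to compound 2 and a 5.3-fold lower number (0.72 log units; beyond the scatter) from compound 3 to compound 4, 13-fold (1.11 log units) apart, beyond the scatter of two such steps The same four compounds, read the other way, show 3-bromo-4-fluorophenyl in place of 4-methoxyphenyl giving a 2.0-fold lower number from compound 2 to compound 4 (0.31 log units; beyond the scatter), which likewise reverses the earlier step: the same change on two cores in this assay, a 6.4-fold higher number (0.81 log units; beyond the scatter) from compound 1 to compound 3 and a 2.0-fold lower number (0.31 log units; beyond the scatter) from compound 2 to compound 4, 13-fold (1.11 log units) apart, beyond the scatter of two such steps In this series, then, neither change carries from one core to another as a fixed step, and the outcome of each differs with the group at the other place, but this rests on a single set of four compounds and does not show why the steps reverse or how general the reversal is.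

The compounds shown leave open whether the reversal would recur with chloro or nitrile in place of trifluoromethyl, or with a longer chain in the shared core. They also leave open whether the same pattern would appear with a carboxylic acid or an amine on either aromatic ring.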